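This account rests on a few compounds, and the source may have more. Where it says the series, first, only, none or still open, it means among the compounds named here.

Compound 1 has the structure `COC(=O)c1nc(C)n(-c2ccccc2)n1`. In a functional assay on NPC-TW01 cells (Homo sapiens) for inhibition, read by MTT assay, with a stated time of 72 h (on this read-out lower numbers stand for stronger inhibition of growth and higher numbers for weaker inhibition of growth), compound 1 gives > 100000 nM, which is a limit of the assay rather than a measured number. Two close relatives have been tested in the same way. Compound 2, with structure `COC(=O)c1nc(C)n(-c2cccc(Br)c2)n1`, gives > 100000 nM in this assay, again a limit. Compound 3, with structure `COC(=O)c1nc(C)n(-c2cccc(C(F)(F)F)c2)n1`, gives > 100000 nM in this assay, likewise a limit. Because (the limit of > 100000 nM in this assay, at which 3 of the 3 values shown sit), none of the steps among these three compounds can be read: a step that the two limits leave unreadable from compound 1 to compound 2, a step that the two limits leave unreadable from compound 1 to compound 3 and a step that the two limits leave unreadable from compound 2 to compound 3 all remain of unreadable size.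

Compound 4, with structure `COC(=O)c1nc(C)n(-c2ccc(Cl)cc2)n1`, is the next member of this small series. It differs from compound 1 in one place: chloro in place of hydrogen on an aromatic carbon. The measured steps that bear on this change are a step that the two limits leave unreadable from compound 1 to compound 2 and a step that the two limits leave unreadable from compound 1 to compound 3, and each of them leads only to another limit, so they offer no readable size in either direction. The expected step is therefore a number no higher from compound 1 to compound 4 (the limit leaves the size open). Compound 4 is expected to give 100000 nM in this assay, within a range from 30000 nM to 300000 nM, and most probably as a limit once more.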

Compound 4, concentration for 50% growth inhibition: 17500 nM
Compound 4: the middle estimate sits 5.7-fold (0.76 log units) above what was measured; the whole stated range lies above it.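

Chloro in place of hydrogen, on an aromatic carbon para to a large group, gives an at least 5.7-fold lower number from compound 1 to compound 4 (0.75 log units; beyond the scatter) in this assay, so this single added chlorine atom is enough to turn a limit into a measured number. Within the data shown here, compound 4 is therefore the first compound in this small series that offers a real value as a starting point for later comparisons, while the steps among compound 1, compound 2 and compound 3 still cannot be read. The step has only a minimum size, with its true size left open, because compound 1 sits at a limit rather than at a measured number: the limit of > 100000 nM in this assay, at which 3 of the 4 values shown sit.

The compounds shown cannot tell whether the gain belongs to chloro itself or to its place on the ring, and a comparison would need other groups at this same position, such as fluoro, methoxy or an amine, as well as chloro at another ring carbon. On these data alone, it also remains open how the methyl ester on the shared core contributes, for instance whether a carboxylic acid or an amide there would keep the growth inhibition seen with compound 4.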